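Swapping the aryl arm: from naphthalene to pyrimidine

This account rests on a few compounds, and the source may have more. Where it says the series, first, only, none or still open, it means among the compounds named here.

Measured compounds:
Compound 1 `Cc1cc(C#N)cc(C)c1Oc1nc(Nc2ccc(C#N)cc2)ncc1-c1ccc2ccccc2c1`: 8460 nM
Compound 2 `Cc1cc(C#N)cc(C)c1Oc1nc(Nc2ccc(C#N)cc2)ncc1-c1ccsc1`: 3920 nM
Compound 3 `COc1ccc(-c2cnc(Nc3ccc(C#N)cc3)nc2Oc2c(C)cc(C#N)cc2C)cc1`: > 279000 nM, a limit of the assay rather than a number

In an ADME assay on MT4 cells (Homo sapiens) for cytotoxicity, read by MTT assay, with a stated time of 5 days (on this read-out lower numbers stand for higher toxicity in this test and higher numbers for lower toxicity in this test), compound 1 gives 8460 nM, the highest of the two plain numbers shown. Its nearest neighbour is reached by a 2.2-fold lower number from compound 1 to compound 2 (0.33 log units; beyond the scatter). For compound 3 the assay reports only a limit, > 279000 nM, so its true value is not known. The other two steps point the same way and are large: an at least 32-fold higher number from compound 1 to compound 3 (1.51 log units; beyond the scatter) and an at least 71-fold higher number from compound 2 to compound 3 (1.85 log units; beyond the scatter), both resting on (the limit of > 279000 nM in this assay, at which 1 of the 3 values shown sits).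

Compound 4 `Cc1cc(C#N)cc(C)c1Oc1nc(Nc2ccc(C#N)cc2)ncc1-c1cncnc1` has not yet been measured. It differs from compound 1 in one place: pyrimidin-5-yl in place of naphthalen-2-yl on an aromatic carbon. Going by the values given here, the closest precedent is the move to a six-membered aryl group in compound 3, which gave the large rise; the thiophene step went modestly the other way. A sizeable rise toward lower toxicity is therefore expected, with a real chance that only a limit is returned.

Compound 4 is estimated at 60000 nM, spanning 10000 nM to 300000 nM. This estimate means a 7.1-fold higher number from compound 1 to compound 4 (0.85 log units; beyond the scatter).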

Compound 4, half-maximal cytotoxic concentration: > 298000 nM
Compound 4 ended at the assay's limit (the forecaster's own chance of this, stated with the estimate: 40%); middle value at least 4.9-fold (0.69 log units) from the limit.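

In this assay, compound 4 returns only a limit of the assay, > 298000 nM. Pyrimidin-5-yl thus joins 4-methoxyphenyl at the top of the measurable range, with an at least 35-fold higher number from compound 1 to compound 4 (1.54 log units; beyond the scatter) and an at least 76-fold higher number from compound 2 to compound 4 (1.88 log units; beyond the scatter), and both steps rest on a limit: the limit of > 298000 nM in this assay, at which 1 of the 4 values shown sits. Among these four compounds, the rise is therefore not tied to one group: two different single-ring six-membered aryl groups, in compound 3 and compound 4, reach a limit, while compound 1 and compound 2 give plain numbers.

Compound 3 and compound 4 both stand as limits, so the step between them cannot be read. Where a plain phenyl group or a pyridin-3-yl group at this position would fall on this read-out remains open.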